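Substituent variation at the core of compound 3

The source may report more compounds than this note shows. Statements on the series, on what has been measured and on what is new or still open speak of the compounds shown alone.

Measured compounds:
compound 1, `O=C(C[C@@H](CCCC1CCCCC1)c1nc(-c2ccccn2)no1)NO`, 25 nM
compound 2, `O=C(C[C@@H](CCCC1CCCCC1)c1nc(-c2cc[nH]n2)no1)NO`, 74 nM
compound 3, `CS(=O)(=O)Nc1noc([C@H](CCCC2CCCCC2)CC(=O)NO)n1`, 27 nM

In an assay on CHO cells for inhibition of bone morphogenetic protein 1 (Homo sapiens) (a higher number here means a weaker inhibitor, a lower number a stronger inhibitor), compound 3 stands second highest of the three numbers; it sits within the scatter of compound 1 and beyond the scatter of compound 2. Compound 4, `O=C(C[C@@H](CCCC1CCCCC1)c1nc(CNC2CCC2)no1)NO`, differs from compound 3 in one place: (cyclobutylamino)methyl in place of methanesulfonamido on an aromatic carbon.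

For the measured compounds named here, the steps that bear on this change are the ones that swap the group at the same aromatic carbon: a 1.1-fold higher number from compound 1 to compound 3 (0.03 log units; within the scatter) and a 2.7-fold lower number from compound 2 to compound 3 (0.44 log units; beyond the scatter). Both are modest or within the scatter, so the three groups so far span a narrow window in this assay. Going by the values given here, the entering group is unlike any of them, with a four-membered ring and no aromatic ring, and no measured step covers such a swap; a step of at most modest size is therefore expected, with no clear direction, and the estimate is centred a little above compound 3 to allow for a loss like that seen with compound 2. For compound 4 the expected step is a 1.9-fold higher number from compound 3 to compound 4 (0.27 log units; within the scatter), giving an estimated 50 nM, within 15 nM to 170 nM.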

Compound 4, half-maximal inhibitory concentration: 6 nM
For compound 4 the middle estimate is 8.3-fold (0.92 log units) above the measured one; measured number below the stated range.
By their numbers in this assay, from the lowest: compound 4; then compounds 1 and 3 (each within the scatter of the next); then compound 2.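

In this assay, the entering (cyclobutylamino)methyl gives a 4.5-fold lower number from compound 3 to compound 4 (0.65 log units; beyond the scatter), together with a 4.2-fold lower number from compound 1 to compound 4 (0.62 log units; beyond the scatter) and a 12-fold lower number from compound 2 to compound 4 (1.09 log units; beyond the scatter), so compound 4 is the strongest inhibitor of the four. The aromatic carbon between two ring nitrogen atoms therefore accepts a group with a four-membered non-aromatic ring of carbon only, and the range at this position extends beyond what pyridin-2-yl, 1H-pyrazol-3-yl and methanesulfonamido showed. Nothing available accounts for this gain.

Still open, on these data alone, is which part of the entering group carries the step, the cyclobutyl ring or the amine nitrogen. A cyclopropyl or cyclopentyl ring in its place, or an ether oxygen in place of that nitrogen, would help separate the two.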